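This account rests on a few compounds, and the source may have more. Where it says the series, first, only, none or still open, it means among the compounds named here.

Three compounds have been measured in a functional assay on HCT-116 cells (Homo sapiens) for cytotoxicity, read by MTT assay, with a stated time of 48 h; on this read-out lower numbers stand for stronger inhibition and higher numbers for weaker inhibition:

Compound 1 `O=C(/C=C\Nc1ccc(F)cc1)c1nc(-c2ccc(C(F)(F)F)cc2)n2ccccc12`: > 30000 nM, a limit of the assay
Compound 2 `O=C(/C=C\Nc1cnc2ccccc2c1)c1nc(-c2ccc(C(F)(F)F)cc2)n2ccccc12`: > 30000 nM, a limit of the assay
Compound 3 `Cc1cc2cc(N/C=C\C(=O)c3nc(-c4ccc(F)cc4)n4ccccc34)ccc2[nH]1`: > 30000 nM, a limit of the assay

Compound 2 therefore stands only at a limit in this assay, with no number of its own. Among the measured compounds shown here, the one step that joins two measured compounds differing in a single place, a step that the two limits leave unreadable from compound 1 to compound 2, carries quinolin-3-yl in place of 4-fluorophenyl on an amine nitrogen, and its size cannot be read, because both ends sit at the limit of > 30000 nM in this assay, at which 3 of the 3 values shown sit. Compound 3, which carries a different aryl group on the amine nitrogen and a 4-fluorophenyl on the core, also sits at that limit.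

Compound 4 `O=C(/C=C\Nc1ccc2cc[nH]c2c1)c1nc(-c2ccc(C(F)(F)F)cc2)n2ccccc12` is not yet measured. It differs from compound 2 as follows: 1H-indol-6-yl in place of quinolin-3-yl on an amine nitrogen. For the measured compounds named here, no measured step shows a size for any change of the amine aryl group, since every value shown is a limit, so the data give no direction for the step from compound 2 to compound 4 beyond what the limit permits. Compound 4 is accordingly expected to sit at or near the same limit, with an estimated step that the limit leaves unreadable from compound 2 to compound 4 in this assay. The estimate for compound 4 is 40000 nM, within a range from 12000 nM to 120000 nM.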

Compound 4, half-maximal inhibitory concentration: > 30000 nM
Compound 4 gave a limit, no number (the forecaster's own chance of this, stated with the estimate: 80%); the middle value lies beyond the limit too.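

Among the compounds shown here, no step from compound 1 or compound 2 to compound 4 can be read, because both ends of each step sit at a limit and not at a number: the limit of > 30000 nM in this assay, at which 4 of the 4 values shown sit. The compounds shown leave open whether any aryl group on the amine nitrogen gives a measurable value in this assay, and how large such a change would be.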